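Replacing pyrimidin-5-yl with cyclohex-1-en-1-yl on the shared core

The source may hold more compounds than are shown below. What is called first, only, known or untested is meant among the compounds shown, and "the series" means these compounds.

In a functional assay on VCaP cells (Homo sapiens) for antiproliferative activity, read by CCK-8 assay, with a stated time of 6 days (on this read-out lower numbers stand for stronger inhibition and higher numbers for weaker inhibition), compound 1 (`CCN(c1ccc(C#N)c(Cl)c1)c1cc(-c2ccncc2)ccc1C`) gives 2900 nM and compound 3 (`CCN(c1ccc(C#N)c(Cl)c1)c1cc(-c2cncnc2)ccc1C`) gives 3920 nM so these two cannot be told apart. Compound 2 (`N#Cc1ccc(N2CCCc3c(-c4ccncc4)cccc32)cc1C(F)(F)F`) gives > 30000 nM which is a limit of the assay and not a number.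

Compound 4 (`CCN(c1ccc(C#N)c(Cl)c1)c1cc(C2=CCCCC2)ccc1C`) keeps the core of compound 3 and differs in one group: cyclohex-1-en-1-yl in place of pyrimidin-5-yl on an aromatic carbon with the change on an aromatic carbon para to a methyl group. For the measured compounds named here, the only measured step that bears on this is a 1.4-fold higher number from compound 1 to compound 3 (0.13 log units; within the scatter) where pyrimidin-5-yl took the place of pyridin-4-yl. That swap stayed within the scatter, but it exchanged one aromatic ring for another, whereas the entering ring here is non-aromatic and carbon only. It is therefore a weak guide, and in this assay no step beyond the scatter is expected. The expected size is a 1.1-fold lower number from compound 3 to compound 4 (0.05 log units; within the scatter) with no clear direction. Going by the values given here, for compound 4 the estimated value is 3500 nM with an expected range from 1000 nM to 12000 nM given the single guiding step.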

Compound 4, half-maximal inhibitory concentration: 20000 nM
Estimate against measurement, compound 4: 5.7-fold (0.76 log units) below, outside the stated range (above it).
By their numbers in this assay, from the lowest: compounds 1 and 3 (each within the scatter of the next); then compound 4. At a limit, above all of these: compound 2.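

For the compounds shown here, the swap between pyridin-4-yl and pyrimidin-5-yl stayed within the scatter, so the earlier compounds gave no sign that this position, para to a methyl group, responds to the group it carries. In this assay the non-aromatic, carbon-only cyclohex-1-en-1-yl gives a 5.1-fold higher number from compound 3 to compound 4 (0.71 log units; beyond the scatter) and also a 6.9-fold higher number from compound 1 to compound 4 (0.84 log units; beyond the scatter), so the group here does matter, at a modest size. No measurement shown accounts for this step.

This change removes both the aromatic ring and its nitrogen atoms, and the compounds shown cannot tell which of the two counts. A phenyl ring, aromatic with carbon only, would separate the two, while a piperidine ring would test a non-aromatic ring that keeps a nitrogen atom.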